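The source may report more compounds than this note shows. Statements on the series, on what has been measured and on what is new or still open speak of the compounds shown alone.

Measured compounds in a functional assay on PC-3 cells (Homo sapiens) for cytotoxicity, with a stated time of 48 h; a higher number here means a weaker inhibitor, a lower number a stronger inhibitor:

compound 1, `O=[N+]([O-])c1ccc(CN2CCC(n3cc(CC(OCc4cc(-c5ccc(F)cc5)no4)c4ccc(Br)cc4)nn3)CC2)cc1` — > 25000 nM
compound 2, `O=[N+]([O-])c1ccc(CN2CCC(n3cc(CC(OCc4cc(-c5cccc(Br)c5)no4)c4ccc(Br)cc4)nn3)CC2)cc1` — > 25000 nM
compound 3, `O=[N+]([O-])c1ccc(CN2CCC(n3cc(CC(OCc4cc(-c5cccc(F)c5)no4)c4ccc(Br)cc4)nn3)CC2)cc1` — 9000 nM

Of these three, compound 3 carries the only numeric result in this assay. For compound 1 the value is a limit of the assay, not a number. For compound 2 the value is likewise a limit. The limit is described by the limit of > 25000 nM in this assay, at which 2 of the 3 values shown sit, and two of the three results sit at it.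

Compound 4, `O=[N+]([O-])c1ccc(CN2CCC(n3cc(CC(OCc4cc(-c5ccccc5Br)no4)c4ccc(Br)cc4)nn3)CC2)cc1`, has not yet been measured. It differs from compound 3 in one place: 2-bromophenyl in place of 3-fluorophenyl on an aromatic carbon.

Among the compounds with values here, two measured steps touch this change. Moving from 4-fluorophenyl to 3-fluorophenyl gave an at least 2.7-fold lower number from compound 1 to compound 3 (0.44 log units; beyond the scatter), and exchanging bromo for fluoro at the 3-position gave an at least 2.7-fold lower number from compound 2 to compound 3 (0.44 log units; beyond the scatter). The step between the two limits, a step that the two limits leave unreadable from compound 1 to compound 2, cannot be sized. Taken together, the fluorine-bearing group of compound 3 is the only one tied to a readable number, and the bromo-bearing group of compound 2 sits at the limit. Within the data shown here, compound 4 carries bromine again, in a third arrangement that no measured compound shows. The expectation for compound 4 is therefore a higher number than compound 3, likely back at the limit: an estimated step of a 3.3-fold higher number from compound 3 to compound 4 (0.52 log units; beyond the scatter). The estimate for compound 4 is 30000 nM, ranging from 9000 nM to 100000 nM.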

Compound 4, half-maximal inhibitory concentration: > 25000 nM
Compound 4: a limit, no number; the forecaster's own chance of this, stated with the estimate: 60%; the middle value lies beyond the limit too.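

In this assay compound 4 gives > 25000 nM and this is a limit of the assay, not a number. Replacing 3-fluorophenyl with 2-bromophenyl on the oxazole carbon next to the ring nitrogen still gives a readable result, an at least 2.7-fold higher number from compound 3 to compound 4 (0.44 log units; beyond the scatter), although this single change alters both the halogen and its place on the phenyl ring. Within the data shown here, with bromine now tried in a second arrangement, 3-fluorophenyl in compound 3 remains the only group here tied to a number, and the steps among compound 1, compound 2 and compound 4 cannot be read, since all three sit at the same end of the range: the limit of > 25000 nM in this assay, at which 3 of the 4 values shown sit.

The compounds shown leave open whether the lower number of compound 3 depends on fluorine itself or on its place on the phenyl ring, a question that a 2-fluorophenyl or a 3-chlorophenyl group would help to separate. As far as these compounds go, how a plain phenyl or a 3-aminophenyl group would read at this position also remains open, as does the true size of every step that ends at the limit.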